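Benzyl ester ring substitution and kinase inhibition at one concentration

This account rests on a few compounds, and the source may have more. Where it says the series, first, only, none or still open, it means among the compounds named here.

Compound 3 `COc1ccc(-c2csc(N)c2C(=O)OCc2ccc(F)cc2)cc1OC` stands lowest of the three measured compounds. In an assay on isolated protein for inhibition of protein kinase C zeta type (Homo sapiens), with stated times of 1 h and 2.5 min, tested at 30 uM (a lower number here means less inhibition, a higher number more inhibition at the concentration tested (going by the name of the read-out)), compound 3 gives 2%. Compound 1 `COc1ccc(-c2csc(N)c2C(=O)OCc2ccccc2)cc1OC` gives 100% in this assay, and compound 2 `COc1ccc(-c2csc(N)c2C(=O)OCc2ccccc2F)cc1OC` gives 100%. The step of no change at the digits printed from compound 1 to compound 2 (within the scatter) shows that fluoro in place of hydrogen on an aromatic carbon can leave the read-out untouched, whereas a number 98 percentage points lower from compound 1 to compound 3 (beyond the scatter) and a number 98 percentage points lower from compound 2 to compound 3 (beyond the scatter) show that the same kind of substitution at another position of the benzyl ring removes essentially all inhibition.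

Compound 4 `COc1ccc(-c2csc(N)c2C(=O)OCc2cccc(C#N)c2)cc1OC` is not yet measured. It differs from compound 3 as follows: 3-cyanophenyl in place of 4-fluorophenyl on a saturated chain carbon bound to an oxygen next to a carbonyl group. Within the data shown here, no measured step covers a cyano group or this position of the benzyl ring, so the three steps bear only indirectly: they show that the read-out swings over its whole range on small changes of this ring, and that a substituent at the position of compound 3 is what lost the activity. Removing that substituent is the part of the change with precedent; the entering group has none. A large rise in this assay is therefore expected, but with wide uncertainty. Compound 4 is estimated at 45%, within 3% to 98%, an expected step of a number 43 percentage points higher from compound 3 to compound 4 (beyond the scatter).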

Compound 4, a percentage reported as inhibition, at one concentration (the size of the read-out at that concentration, not a potency): 70%
For compound 4 the middle estimate is 25 percentage points below the measured one, within the range that was stated.
By their numbers in this assay, from the lowest: compound 3; then compound 4; then compounds 1 and 2 (each within the scatter of the next).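

Working notes on the benzyl ester. In this assay a group on this benzyl ring need not remove inhibition, as 3-cyanobenzyl in place of 4-fluorobenzyl gives a number 68 percentage points higher from compound 3 to compound 4 (beyond the scatter) and so recovers much of the read-out at the one concentration tested. Inhibition is not fully retained either: cyano in place of hydrogen gives a number 30 percentage points lower from compound 1 to compound 4 (beyond the scatter) and 3-cyanophenyl in place of 2-fluorophenyl gives a number 30 percentage points lower from compound 2 to compound 4 (beyond the scatter) in the same assay, so compound 4 stands at an intermediate level and the series no longer divides into only full and near-absent inhibition. No measurement at hand accounts for these differences in the read-out.

The step between compound 3 and compound 4 changes both the group and its place on the ring, and the compounds shown do not separate these two contributions. They also leave open how this assay responds to other groups on the benzyl ring, such as an amine, a carboxylic acid or a longer chain, and how any of these esters ranks in a full concentration series rather than at a single concentration.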